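Trimethoxyphenyl pyrazole chalcones: cytotoxicity at a single concentration

A few compounds are considered here, and "the series" means these few. Any claim that something is new, unique, unknown or untested is made for them only; others in the source may bear on it.

Measured compounds and their read-outs:
compound 1 `COc1cc(-c2cc(/C=C/C(=O)c3ccc(N)cc3)[nH]n2)cc(OC)c1OC` — 95%
compound 2 `COc1ccc(C(=O)/C=C/c2cc(-c3cc(OC)c(OC)c(OC)c3)n[nH]2)cc1OC` — 101%

In a functional assay on SW-620 cells (Homo sapiens) for cytotoxicity, read by sulforhodamine B assay, with a stated time of 48 h, tested at 0.01 uM (on this read-out higher numbers stand for a weaker effect at the one concentration tested and lower numbers for a stronger effect), compound 1 gives 95% and compound 2 gives 101%. Compound 2 stands highest of the two numbers; the nearest is compound 1, and the step of a number 6 percentage points higher from compound 1 to compound 2 (within the scatter) is within the scatter, so the two values cannot be ordered.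

Compound 3 `COc1cc(C(=O)/C=C/c2cc(-c3cc(OC)c(OC)c(OC)c3)n[nH]2)cc(OC)c1OC` has not been measured. It differs from compound 2 by methoxy in place of hydrogen on an aromatic carbon, the change sitting on an aromatic carbon of a six-membered aromatic ring of carbon only, ortho to a methoxy group and meta to a methoxy group.

Among the compounds with values here, only one measured step exists, a number 6 percentage points higher from compound 1 to compound 2 (within the scatter), and it concerns a different change, an aryl swap on the carbonyl carbon, not a methoxy for hydrogen. Within the data shown here, no measured step bears directly on the change from compound 2 to compound 3. Given that the one step seen, a number 6 percentage points higher from compound 1 to compound 2 (within the scatter), stayed within the scatter, no step beyond the scatter is expected for compound 3 in this assay, and the expected step is a number 3 percentage points lower from compound 2 to compound 3 (within the scatter). Compound 3 is therefore estimated at 98%, with a range from 85% to 110%.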

Compound 3, a percentage reported as activity, at one concentration (the size of the read-out at that concentration, not a potency): 96%
Compound 3: the middle estimate sits 2 percentage points above what was measured, and the stated range covers the measured number.
By their numbers in this assay, from the lowest: compounds 1, 3 and 2 (each within the scatter of the next).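

In this assay, within the data shown here, the new pair gives the first reading on a substitution within the ring rather than on an exchange of the whole aryl group on the carbonyl carbon: methoxy in place of hydrogen, on an aromatic carbon of a six-membered aromatic ring of carbon only, ortho to a methoxy group and meta to a methoxy group, gives a number 5 percentage points lower from compound 2 to compound 3 (within the scatter). At this one concentration, the added methoxy, with its 2 heavy atoms, therefore does not separate the two compounds, and the read-out of the series gains no order from this change. No measurement at hand accounts for this result.

As far as these compounds go, whether an amine, a hydroxy group or a chlorine atom on the same aromatic carbon would separate from compound 2 in this assay stays open. The read-out also gives the size of an effect at a single concentration and not a potency, so how the methoxy step reads at higher concentrations remains an open question.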